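The source may hold more compounds than are shown below. What is called first, only, known or untested is meant among the compounds shown, and "the series" means these compounds.

In an ADME assay on the whole organism (Rattus norvegicus, strain Sprague-Dawley) for pharmacokinetics, read by LC-MS, with a stated time of 30 min (a lower number here means that more of the compound stays in the plasma, a higher number that more of the compound sits outside the plasma), compound 1 `N#Cc1ccc(O[C@H]2CN(S(=O)(=O)c3ccc(Cl)cc3Cl)C[C@@]2(O)CO)cc1F` gives 3.2 L/kg and holds the lower of the two numbers, with compound 2 `N#Cc1ccc(O[C@H]2CN(S(=O)(=O)c3ccc(Cl)cc3Cl)C[C@]2(O)CO)cc1F` at 13 L/kg on the higher side. Among the measured compounds shown here, the one measured step of a 4.1-fold higher number from compound 1 to compound 2 (0.61 log units; beyond the scatter) comes with the fact that compounds 1 and 2 differ only in the configuration as drawn and does not concern ring substitution. For the measured compounds named here, compound 3 `N#Cc1ccc(O[C@H]2CN(S(=O)(=O)c3ccc(Cl)cc3)C[C@@]2(O)CO)cc1F` differs from compound 1 as 2,4-dichlorophenyl to 4-chlorophenyl hydrogen in place of chloro on an aromatic carbon and no measured step bears on this change. No step beyond the scatter is therefore expected in this assay for hydrogen in place of chloro. The estimated step of a 1.1-fold lower number from compound 1 to compound 3 (0.06 log units; within the scatter) is small. Compound 3 is expected at 2.8 L/kg with 1.4 L/kg to 5.6 L/kg as the estimated range.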

Compound 3, volume of distribution at steady state in the Rattus norvegicus assay: 6 L/kg
Estimate against measurement, compound 3: 2.1-fold (0.33 log units) below; measured number outside the range, above it.
By their numbers in the Rattus norvegicus assay, from the lowest: compounds 1 and 3 (each within the scatter of the next); then compound 2.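

In the Rattus norvegicus assay hydrogen in place of chloro on an aromatic carbon, ortho to a large group, gives a 1.9-fold higher number from compound 1 to compound 3 (0.27 log units; within the scatter), so this position gives up the chloro without a step beyond the scatter. The earlier pair spoke only to configuration: the fact that compounds 1 and 2 differ only in the configuration as drawn. In a physicochemical assay for solubility, in simulated intestinal fluid, with a stated time of 4 h (a lower number here means a less soluble compound, a higher number a more soluble compound), compound 1 gives 19 ug/mL and compound 3 gives 44 ug/mL. The same change does show in solubility as measured: the measured solubility of compound 1, 19 ug/mL, and of compound 3, 44 ug/mL, a 2.3-fold higher number (0.36 log units; beyond the scatter).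

Open, going by these compounds, is how a methoxy group or an amine on this aromatic carbon would read in either measurement. Also open, on these data alone, is whether the chloro change reads the same in the configuration of compound 2.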